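The source may report more compounds than this note shows. Statements on the series, on what has been measured and on what is new or still open speak of the compounds shown alone.

Compound 3 `Cc1cccc(C#Cc2ccc3c(n2)CCN(C)C3=O)c1` is the only one of the three measured compounds for which an assay on HEK293 cells for displacement of a labelled ligand from metabotropic glutamate receptor 5 (Homo sapiens), with a stated time of 2 h (a lower number here means a stronger inhibitor, a higher number a weaker inhibitor), reports a number: in this assay compound 3 gives 820 nM. Compound 1 `O=C(NC1CCCC1)c1ccc(C#Cc2cccnc2)nc1` reaches only a limit of this assay, > 32000 nM. Compound 2 `Cc1ccccc1C#Cc1ccc2c(n1)CCN(C)C2=O` likewise sits at a limit of this assay, > 32000 nM. Among the compounds with values here, the single step of measured size runs an at least 39-fold lower number from compound 2 to compound 3 (1.59 log units; beyond the scatter), so that moving the methyl on the phenyl ring carried the value from a limit to a real number. Compound 4 `Cc1ccc(C#Cc2ccc3c(n2)CCN(C)C3=O)cc1` differs from compound 3 by 4-methylphenyl in place of 3-methylphenyl on a triple-bonded carbon. Within the data shown here, this change touches the same methylphenyl group on the same triple-bonded carbon as the measured step, but no measured pair covers the 4-methylphenyl arrangement itself, so the direction can only be guessed from the sensitivity the measured step revealed. Because two of three values rest at the limit of > 32000 nM in this assay, at which 2 of the 3 values shown sit, a limit for compound 4 remains possible. Compound 4 is expected to give 3500 nM, in a range from 800 nM to 25000 nM. The expected step of a 4.3-fold higher number from compound 3 to compound 4 (0.63 log units; beyond the scatter) is therefore a weakening.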

Compound 4, inhibition constant: 7450 nM
For compound 4 the middle estimate is 2.1-fold (0.33 log units) below the measured one; low and high end bracket the measured number.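

The methyl group on the phenyl ring can now be compared in all three arrangements on the triple-bonded carbon, and the change from 3-methylphenyl to 4-methylphenyl runs a 9.1-fold higher number from compound 3 to compound 4 (0.96 log units; beyond the scatter). Thus the loss seen with the earlier move of the methyl group is not confined to the 2-methylphenyl arrangement, and in both steps that involve it the 3-methylphenyl arrangement gives the lower number. The 4-methylphenyl arrangement still keeps a measurable number, with an at least 4.2-fold lower number from compound 2 to compound 4 (0.63 log units; beyond the scatter), so the three arrangements are separated in this assay even though the groups have the same atoms.

Going by these compounds, whether a chlorine atom, a methoxy group or an unsubstituted phenyl ring would follow the same order remains open. The size of both steps from compound 2 also remains open, as each is only a bound: the limit of > 32000 nM in this assay, at which 2 of the 4 values shown sit.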